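The compounds below may be only part of what the source reports. "The series", "measured", "known", "first", "only" and "open" are said of these compounds alone.

Compound 3 `CC1=C(C(=O)Nc2ccc(F)cc2)C(c2ccc([N+](=O)[O-])cc2)n2c(s/c(=C/c3ccc(Cl)cc3Cl)c2=O)=N1` stands highest of the three numbers in a functional assay on the whole organism (strain albino) for inhibition, with Rattus norvegicus as the target, read by paw edema, with stated times of 1 h and 3 h, at a dose of 25 mg/kg by the oral route (on this read-out higher numbers stand for more inhibition at the one dose given (going by the name of the read-out) and lower numbers for less inhibition), where compound 3 gives 17%. Compound 1 `CC1=C(C(=O)Nc2ccc(F)cc2)C(c2ccc(Br)cc2)n2c(s/c(=C/c3ccc(Cl)cc3Cl)c2=O)=N1` gives 14%, and the step of a number 3 percentage points higher from compound 1 to compound 3 (within the scatter) lies within the scatter. Compound 2 `CC1=C(C(=O)Nc2ccc(F)cc2)C(c2ccc(Br)cc2)n2c(s/c(=C/c3ccccc3)c2=O)=N1` gives 5%, which lies beyond the scatter from compound 3. Compound 4 `CC1=C(C(=O)Nc2ccc(F)cc2)C(c2ccc([N+](=O)[O-])cc2)n2c(s/c(=C/c3ccccc3Cl)c2=O)=N1` differs from compound 3 by hydrogen in place of chloro on an aromatic carbon. The measured step that bears on this is the one in which phenyl replaces 2,4-dichlorophenyl, a number 9 percentage points lower from compound 1 to compound 2 (within the scatter), a larger change of the same kind that stays within the scatter. A smaller change is expected to move the number little, so the step of a number 4 percentage points lower from compound 3 to compound 4 (within the scatter) is estimated to stay within the scatter, if anything slightly downward. Compound 4 is therefore expected to give about 13%, between 4% and 24%.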

Compound 4, a percentage reported as inhibition, in the whole organism at one dose (the size of the read-out at that dose, not a potency): 19%
For compound 4 the middle estimate is 6 percentage points below the measured one; the measured number falls inside the stated range.
By their numbers in this assay, from the lowest: compounds 2, 1, 3 and 4 (each within the scatter of the next, the first and the last beyond it).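

In this assay, replacing chloro with hydrogen, which turns 2,4-dichlorophenyl into 2-chlorophenyl, gives a number 2 percentage points higher from compound 3 to compound 4 (within the scatter). This single change at this position, made with the nitro group in place, therefore leaves the two compounds indistinguishable in this read-out. No measurement shown here offers an explanation for this result.

The compounds shown leave open whether an amine or a carboxylic acid on this aromatic carbon would move the number beyond the scatter. Also open, as far as these compounds go, is what replacing the remaining chloro group would do.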